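The compounds below may be only part of what the source reports. "The series", "measured", "known", "first", "only" and "open" are said of these compounds alone.

In an ADME assay on BHK cells (Mesocricetus auratus) for cytotoxicity, read by MTT assay (on this read-out lower numbers stand for higher toxicity in this test and higher numbers for lower toxicity in this test), compound 1 (`OC[C@@H]1[C@@H](O)[C@H](O)[C@@H](O)CN1CCCCCCOc1cc(F)ccc1F`) gives > 500000 nM as a limit of the assay, not a number. Compound 2 (`OC[C@@H]1[C@@H](O)[C@H](O)[C@@H](O)CN1CCC#CCCOc1cc(F)ccc1F`) gives > 500000 nM as a limit too. Among the measured compounds shown here, compound 1 thus stands at the limit of > 500000 nM in this assay, at which 2 of the 2 values shown sit, and no step between measured compounds is available. Compound 3 (`CC1CCC(OCCCCCCN2C[C@H](O)[C@@H](O)[C@H](O)[C@H]2CO)CC1C`) differs from compound 1 by one change (a group of 8 heavy atoms (8 carbon; one six-membered non-aromatic ring of carbon only) in place of a group of 8 heavy atoms (6 carbon, 2 fluorine; one six-membered aromatic ring of carbon only), on an oxygen on a saturated carbon), a non-aromatic ring in place of the 2,5-difluorophenyl, on an oxygen on a saturated carbon. Only a small estimated step (an at least 1.1-fold lower number from compound 1 to compound 3 (0.04 log units; that floor lies within the scatter)) towards lower numbers is expected in this assay or none beyond the scatter. The expected value for compound 3 is 450000 nM in an estimated range from 150000 nM to 800000 nM on this read-out.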

Compound 3, half-maximal cytotoxic concentration: > 500000 nM
Compound 3: a limit, no number; the forecaster's own chance of this, stated with the estimate: 65%; middle value at least 1.1-fold (0.04 log units) from the limit.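

Compound 3, like compound 1, gives only a limit, so no step from compound 1 to compound 3 can be read in this assay: the limit of > 500000 nM in this assay, at which 3 of the 3 values shown sit.

The compounds shown leave open at what concentration, if any, each would turn toxic in this test.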